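The source may report more compounds than this note shows. Statements on the series, on what has been measured and on what is new or still open speak of the compounds shown alone.

In a functional assay on HUVEC cells (Homo sapiens) (on this read-out lower numbers stand for an effect already at smaller amounts and higher numbers for an effect only at larger amounts of compound), compound 1 `Cc1c(O)c(C)c2c(c1O)C(=O)CC(c1ccccc1[N+](=O)[O-])O2` gives > 5000 nM, which is a limit and not a number. Compound 2 `COc1ccccc1C1CC(=O)c2c(O)c(C)c(O)c(C)c2O1` gives > 20000 nM, also a limit. For the measured compounds named here, the only measured step is a step that the two limits leave unreadable from compound 1 to compound 2, with methoxy in place of nitro on an aromatic carbon, so it offers no size to carry forward. Compound 3 `COc1ccc(C2CC(=O)c3c(O)c(C)c(O)c(C)c3O2)c(OC)c1` changes compound 2 in one place: methoxy in place of hydrogen on an aromatic carbon. With only the limit of > 20000 nM for compound 2 as a guide, no step beyond the usual scatter is expected in this assay. The expected step is a number no higher from compound 2 to compound 3 (the limit leaves the size open). For compound 3 the estimate is 20000 nM, with an expected range from 7000 nM to 45000 nM.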

Compound 3, half-maximal effective concentration: "not active" (no number reported)
The entry for compound 3 holds no number; the estimate stays without a comparison.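

No step can be read from compound 2 to compound 3: compound 3 is reported as "not active" without a number, and compound 2 has only a limit. How far any of these methoxy changes moves the result in this assay stays open: none of the three compounds shown has an exact number.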